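Compound 4, the open-chain analogue of compound 2

The source may report more compounds than this note shows. Statements on the series, on what has been measured and on what is new or still open speak of the compounds shown alone.

Of the compounds shown here, three have numbers so far. In a functional assay on the whole organism (Tail, strain ICR) with Mus musculus as the target, in the tail flick test, with a stated time of 120 min, at a dose of 25 umol/kg by the oral route (on this read-out lower numbers stand for a weaker effect and higher numbers for a stronger effect at the one dose given), compound 1 `NC(=O)CC[C@H](NC(=O)CN(c1ncnc2c1ncn2C1CCCCO1)C1CC1)C(=O)OCc1ccccc1` gives 22.3%, compound 2 `O=C(O)[C@@H]1CCCN1C(=O)CN(c1nc(Cl)nc2[nH]cnc12)C1CC1` gives 23.6%, and compound 3 `O=C(OCc1ccccc1)[C@@H]1CCCN1C(=O)CN(c1nc(Cl)nc2[nH]cnc12)C1CC1` gives 38.4%. For the measured compounds named here, compound 2 stands second of the three numbers; its value and that of compound 1 lie within the scatter of each other, while compound 3 is the one measured compound beyond the scatter from it, a number 14.8 percentage points higher from compound 2 to compound 3 (beyond the scatter).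

Compound 4 `O=C(O)CNC(=O)CN(c1nc(Cl)nc2[nH]cnc12)C1CC1` is not yet measured. It differs from compound 2 in one place: (carboxymethyl)amino in place of 2-carboxypyrrolidin-1-yl on a carbonyl carbon. Going by the values given here, no measured step touches this part of the molecule. Among the compounds with values here, the single step with a direction, from compound 2 to compound 3, concerns the benzyl in place of hydrogen on an oxygen next to a carbonyl group and says nothing about the carbonyl carbon where compound 4 changes. Within the data shown here, with no bearing step, no movement beyond the scatter is expected in this assay from compound 2 to compound 4, a number 0.4 percentage points higher from compound 2 to compound 4 (within the scatter). Compound 4 is therefore estimated at 24%, within 12% to 37%, a value close to that of compound 2 23.6%.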

Compound 4, a percentage reported as activity, at one dose (the size of the read-out at that dose, not a potency): 19.8%
For compound 4 the middle estimate is 4.2 percentage points above the measured one; measured number inside the range.
By their numbers in this assay, from the lowest: compounds 4, 1 and 2 (each within the scatter of the next); then compound 3.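

In this assay, for the compounds shown here, (carboxymethyl)amino in place of 2-carboxypyrrolidin-1-yl on a carbonyl carbon gives a number 3.8 percentage points lower from compound 2 to compound 4 (within the scatter) and is the first reading at this place. Compound 2 and compound 4 therefore show that, at the one dose given, losing the five-membered non-aromatic ring and the defined stereocentre does not shift the read-out beyond the scatter while the carboxy group stays. Nothing measured here accounts for this result.

On these data alone, it remains open whether a longer chain bearing the carboxylic acid, or a simple amine without it, on this carbonyl carbon would keep the read-out within the scatter of compound 2. Going by these compounds alone, the benzyl step seen as a number 14.8 percentage points higher from compound 2 to compound 3 (beyond the scatter) also has no counterpart yet on compound 4, so its transfer to the open chain is unknown.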